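The source may hold more compounds than are shown below. What is called first, only, known or untested is meant among the compounds shown, and "the series" means these compounds.

Measured so far:
- compound 1, `CCOc1ccc(Cc2nnc(CN(c3cccc(Cl)c3C)S(=O)(=O)c3ccc(C)cc3)o2)cc1`: 3.98 nM
- compound 2, `Cc1ccc(S(=O)(=O)N(Cc2nnc(Cc3ccccc3F)o2)c2cccc(Cl)c2C)cc1`: 501 nM
- compound 3, `Cc1ccc(S(=O)(=O)N(Cc2nnc(Cc3ccccc3Cl)o2)c2cccc(Cl)c2C)cc1`: 79.4 nM

In an assay on CHO cells for displacement of a labelled ligand from prostaglandin E2 receptor EP1 subtype (Homo sapiens) (a higher number here means a weaker inhibitor, a lower number a stronger inhibitor), compound 3 stands second of the three, with compound 2 giving the weaker number a 6.3-fold lower number from compound 2 to compound 3 (0.80 log units; beyond the scatter) and compound 1 the stronger a 20-fold higher number from compound 1 to compound 3 (1.30 log units; beyond the scatter).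

Compound 4, `COc1ccc(NCc2nnc(CN(c3cccc(Cl)c3C)S(=O)(=O)c3ccc(C)cc3)o2)cc1`, is the next step from compound 3: (4-methoxyphenyl)amino in place of 2-chlorophenyl on a saturated chain carbon bound to an aromatic carbon. For the measured compounds named here, no measured pair covers an amino linker at this position. Going by the values given here, the one step that bears on it is the move from a para-alkoxyphenyl to an ortho-halophenyl, a 20-fold higher number from compound 1 to compound 3 (1.30 log units; beyond the scatter), which was large, so a para-methoxy aryl returning at this site is expected to pull the number down again, though the inserted amine leaves the size uncertain. The step is therefore expected as a 4.0-fold lower number from compound 3 to compound 4 (0.60 log units; beyond the scatter). Compound 4 is estimated at 20 nM, between 3 nM and 150 nM.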

Compound 4, half-maximal inhibitory concentration: 20 nM
Compound 4: the middle estimate sits on the measured number at the digits printed; the range from low to high includes it.
By their numbers in this assay, from the lowest: compound 1; then compound 4; then compound 3; then compound 2.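

With (4-methoxyphenyl)amino on the saturated chain carbon, this assay shows a 4.0-fold lower number from compound 3 to compound 4 (0.60 log units; beyond the scatter) and also a 25-fold lower number from compound 2 to compound 4 (1.40 log units; beyond the scatter) so an amino-linked aryl carrying an alkoxy group gives a stronger number than either halophenyl group. It still falls short of 4-ethoxyphenyl, with a 5.0-fold higher number from compound 1 to compound 4 (0.70 log units; beyond the scatter) in a change that alters the alkoxy group and the linker together. No evidence on the cause of these steps is available.

The compounds shown do not separate the contribution of the amino linker from that of the alkoxy group. A 4-methoxybenzyl or (4-ethoxyphenyl)amino group at this place would bear on that question.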